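Swapping the aminopyridine arm for a piperidine

The source may report more compounds than this note shows. Statements on the series, on what has been measured and on what is new or still open speak of the compounds shown alone.

Compound 2 `CCC(C)(C)Cc1c[nH]c(CCc2ccc(-c3cccc(N)n3)cc2)n1` gives 97 nM in a functional assay on HEK293 cells for agonist activity at Bombesin receptor subtype-3 (Homo sapiens), read by luminescence and calcium flux, with a stated time of 10 min; on this read-out lower numbers stand for an effect already at smaller amounts and higher numbers for an effect only at larger amounts of compound. Compound 1 `CCC(C)(C)Cc1c[nH]c(CCc2ccc(-c3ccccc3C(=O)O)cc2)n1` gives 101 nM in this assay, so the two stand side by side within the scatter. The step of a 1.0-fold lower number from compound 1 to compound 2 (0.02 log units; within the scatter) confirms this. Compound 3 `CCC(C)(C)Cc1c[nH]c(CCc2ccc(N3CCCCC3)cc2)n1` differs from compound 2 by piperidin-1-yl in place of 6-aminopyridin-2-yl on an aromatic carbon. Among the measured compounds shown here, the one measured step exchanged the arm at this same site without a shift beyond the scatter, so the step of a 1.5-fold higher number from compound 2 to compound 3 (0.19 log units; within the scatter) is expected to be small, if anything a slight rise in number. For compound 3 the estimate is 150 nM, ranging from 50 nM to 500 nM.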

Compound 3, half-maximal effective concentration: 108 nM
Compound 3: the middle estimate sits 1.4-fold (0.14 log units) above what was measured; measured number inside the range.
By their numbers in this assay, from the lowest: compounds 2, 1 and 3 (each within the scatter of the next).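

In this assay, the aromatic carbon para to a large group now also takes a non-aromatic ring: piperidin-1-yl, with 0 hydrogen-bond donors, leaves the number within the scatter (a 1.1-fold higher number from compound 2 to compound 3 (0.05 log units; within the scatter); a 1.1-fold higher number from compound 1 to compound 3 (0.03 log units; within the scatter)). Among these three compounds, then, neither an aromatic arm nor a hydrogen-bond donor in the arm is needed to keep the number in this range. Nothing at hand explains why these exchanges change so little.

Still open, from the compounds shown here alone, is whether a plain amine, a morpholine or a longer chain on this carbon would hold the number. Also open, going by these compounds, is whether any group here gives a step beyond the scatter.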